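Moving the chlorine on a diketopiperazine-like pair of benzylidene arms

A few compounds are considered here, and "the series" means these few. Any claim that something is new, unique, unknown or untested is made for them only; others in the source may bear on it.

Compound 1, with the structure `C=CCn1c(=O)/c(=C\c2cccc(Cl)c2)[nH]c(=O)/c1=C\c1ccccc1OC`, is the starting point. In a functional assay on NCI-H1975 cells (Homo sapiens) for cytotoxicity, read by CCK-8 assay, with a stated time of 72 h (a lower number here means a stronger inhibitor, a higher number a weaker inhibitor), compound 1 gives 5100 nM. Compound 2, with the structure `COc1ccccc1/C=c1/[nH]c(=O)/c(=C\c2ccccc2OC)n(C)c1=O`, carries a methyl group and two 2-methoxyphenyl arms; in this assay compound 2 gives 16900 nM. Compound 3, with the structure `COc1ccccc1/C=c1/[nH]c(=O)/c(=C\c2cccc(Cl)c2Cl)[nH]c1=O`, carries a 2,3-dichlorophenyl arm and no group on the ring nitrogen; for compound 3 this assay reports only "not active" (no number reported), with no number attached. Among the two numbers that exist, compound 1 holds the lower one, and the gap to compound 2 lies beyond the usual scatter.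

Compound 4, with the structure `C=CCn1c(=O)/c(=C\c2ccccc2Cl)[nH]c(=O)/c1=C\c1ccccc1OC`, differs from compound 1 in one place: 2-chlorophenyl in place of 3-chlorophenyl on a double-bonded chain carbon bound to an aromatic carbon. Going by the values given here, no pair of measured compounds separated by this same change is available, so nothing in the data sets the size of this step directly. The account therefore expects no change beyond the scatter, with a slight lean toward a higher number in light of compound 3, which gives "not active" (no number reported), and of compound 2, which gives 16900 nM. Compound 4 is estimated to give 6500 nM in this assay, within a range from 2500 nM to 17000 nM. The expected step of a 1.3-fold higher number from compound 1 to compound 4 (0.11 log units; within the scatter) would thus stay within the scatter.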

Compound 4, half-maximal inhibitory concentration: 9200 nM
Beside the measured number, compound 4's estimate is 1.4-fold (0.15 log units) below it; measured number inside the range.
By their numbers in this assay, from the lowest: compounds 1, 4 and 2 (each within the scatter of the next, the first and the last beyond it).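

In this assay, moving the chlorine, with 2-chlorophenyl in place of 3-chlorophenyl on a double-bonded chain carbon bound to an aromatic carbon, gives a 1.8-fold higher number from compound 1 to compound 4 (0.26 log units; within the scatter). This is the only comparison here between compounds that differ in one place, and it shows that this read-out does not separate these two chlorophenyl arms on the core of compound 1, so the position of the chlorine on this arm has not been shown to matter in this assay. No measurement of any property of these compounds bears on this step, and the data offer no account of what lies behind it.

The compounds shown leave open whether the same arm would keep its number in this assay if the chlorine gave way to a different substituent altogether, such as an amine or a carboxylic acid. They also leave open how far the result depends on the chain on the ring nitrogen of compound 1, since the effect of a longer chain or a hydroxyethyl group there cannot be read from these compounds.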